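The source may hold more compounds than are shown below. What is called first, only, known or untested is meant among the compounds shown, and "the series" means these compounds.

Working notes on the series in a functional assay on DU-145 cells (Homo sapiens) for inhibition, read by trypan blue exclusion, with a stated time of 96 h; on this read-out lower numbers stand for stronger inhibition of growth and higher numbers for weaker inhibition of growth. Compound 1 `O=C(/C(=C\c1csc([N+](=O)[O-])c1)S(=O)(=O)c1ccc(Br)cc1)c1ccc(Br)cc1` gives 1000 nM in this assay, the lowest of the two numbers in hand. Compound 2 `O=C(/C(=C\c1ccc(O)c([N+](=O)[O-])c1)SCc1ccc(Cl)cc1)c1ccc(Cl)cc1` gives 10000 nM in this assay, a gap from compound 1 that lies beyond the scatter; compound 2 differs from compound 1 in several places at once, so the two values are compared only as values. Compound 3 `O=C(/C(=C\c1ccc(F)cc1F)S(=O)(=O)c1ccc(Br)cc1)c1ccc(Br)cc1` is not yet measured and differs from compound 1 by 2,4-difluorophenyl in place of 5-nitrothiophen-3-yl on a double-bonded chain carbon bound to a double-bonded chain carbon. Within the data shown here, no step between measured compounds that differ in one place is available, so the size of this change has to be guessed. Compound 3 is expected to give 2000 nM in this assay, within a range of 500 nM to 8000 nM. The expected step of a 2.0-fold higher number from compound 1 to compound 3 (0.30 log units; within the scatter) is a small loss, close to the edge of the scatter.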

Compound 3, concentration for 50% growth inhibition: 7500 nM
Compound 3: middle estimate off by 3.8-fold (0.57 log units), on the low side; measured number inside the range.
By their numbers in this assay, from the lowest: compound 1; then compounds 3 and 2 (each within the scatter of the next).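

In this assay this position proves sensitive to the ring it carries: 2,4-difluorophenyl in place of 5-nitrothiophen-3-yl on a double-bonded chain carbon bound to a double-bonded chain carbon gives the series its first single-place step (a 7.5-fold higher number from compound 1 to compound 3 (0.88 log units; beyond the scatter)), a modest loss of growth inhibition. The two groups have the same heavy-atom count, so that count does not separate them; they differ in ring type and in hydrogen-bond acceptors, as the entering group has none. Nothing in hand accounts for this loss.

From the compounds shown here alone, the change replaces the ring and its substituents at once, so the share of the nitro group, the thiophene ring and the fluorines stays open. Going by these compounds, how an amine or a carboxylic acid on the ring at this position would behave also remains open.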